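The compounds below may be only part of what the source reports. "The series", "measured", "known", "first", "only" and "open" are said of these compounds alone.

Measured compounds:
Compound 1 `Nc1nc(-c2cnco2)nc2sc(Cc3ccccc3)cc12` — in a functional assay on CHO-K1 cells for antagonist activity at adenosine receptor A1 (Homo sapiens), read by a beta-galactosidase reporter and cAMP accumulation, with stated times of 15 min and 6 h (on this read-out lower numbers stand for stronger inhibition and higher numbers for weaker inhibition), compound 1 gives 106 nM.
Compound 2 `Cc1csc(-c2nc(N)c3cc(Cc4ccccc4)sc3n2)n1` — in this assay compound 2 gives 1490 nM.
Compound 3 `C=C(c1ccccc1)c1cc2c(N)nc(-c3nc(C)cs3)nc2s1` — in this assay compound 3 gives only a limit, > 594 nM, and no number.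

Of the two real numbers, compound 2 stands highest, meaning the weakest inhibition shown; its nearest neighbour is compound 1, and the step of a 14-fold higher number from compound 1 to compound 2 (1.15 log units; beyond the scatter) lies well beyond the scatter. Compound 3 contributes a limit, not a number (the limit of > 594 nM in this assay, at which 1 of the 3 values shown sits).

Compound 4 `Nc1nc(-c2ccccn2)nc2sc(Cc3ccccc3)cc12` differs from compound 2 by pyridin-2-yl in place of 4-methyl-1,3-thiazol-2-yl on an aromatic carbon. Within the data shown here, the only measured step at this same position is a 14-fold higher number from compound 1 to compound 2 (1.15 log units; beyond the scatter), which shows that changing the ring there moves the number strongly. The step that the limit leaves unreadable from compound 2 to compound 3 concerns another place and is not readable. Since a ring change at this position already produced a large shift in one direction, a sizeable shift back toward the lower number of compound 1 is expected for compound 4, estimated as a 5.0-fold lower number from compound 2 to compound 4 (0.70 log units; beyond the scatter). Compound 4 is therefore expected near 300 nM, in a range from 60 nM to 1500 nM.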

Compound 4, inhibition constant: 3710 nM
The estimate for compound 4 lay 12-fold (1.09 log units) below the measured number, and the stated range ends below it.
By their numbers in this assay, from the lowest: compound 1; then compound 2; then compound 4.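

At this position, on the aromatic carbon between two ring nitrogen atoms, pyridin-2-yl does not bring the number back toward that of compound 1: in this assay the change gives a 2.5-fold higher number from compound 2 to compound 4 (0.40 log units; beyond the scatter), and the full distance from the 1,3-oxazol-5-yl compound grows to a 35-fold higher number from compound 1 to compound 4 (1.54 log units; beyond the scatter). Both rings shown in place of 1,3-oxazol-5-yl, the five-membered 4-methyl-1,3-thiazol-2-yl and the six-membered pyridin-2-yl, therefore give weaker inhibition, so among these three compounds 1,3-oxazol-5-yl gives the strongest. Nothing measured here accounts for this order.

As far as these compounds go, it remains open whether another five-membered ring, such as furan-2-yl, or a non-ring group, such as an amine, would match or beat 1,3-oxazol-5-yl here. From the compounds shown here alone, it is also open whether the same order would hold with 1-phenylethenyl in place of benzyl.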